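The compounds below may be only part of what the source reports. "The series", "measured", "known", "first", "only" and "open" are said of these compounds alone.

Compound 1 `Cc1ccccc1S(=O)(=O)Nc1ccc2oc(-c3ccccc3)nc2c1`: in an assay on cells for inhibition of HSP60/HSP10 (Homo sapiens), with a stated time of 60 min (a higher number here means a weaker inhibitor, a lower number a stronger inhibitor), compound 1 gives > 100000 nM, which is a limit of the assay.
Compound 2 `O=S(=O)(Nc1ccc2oc(-c3ccccc3)nc2c1)c1cccc(F)c1`: compound 2 gives > 100000 nM, again a limit.
Compound 3 `COc1ccc(S(=O)(=O)Nc2ccc3oc(-c4ccccc4)nc3c2)cc1`: compound 3 gives > 100000 nM, also a limit.

All three measured compounds share one core and differ only in the aromatic group on the sulfonyl sulfur. Because (the limit of > 100000 nM in this assay, at which 3 of the 3 values shown sit), none of them has a readable number in this assay; each sits at the same limit. The steps between them, a step that the two limits leave unreadable from compound 1 to compound 2, a step that the two limits leave unreadable from compound 1 to compound 3 and a step that the two limits leave unreadable from compound 2 to compound 3, therefore cannot be sized.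

Compound 4 `Cc1cccc(S(=O)(=O)Nc2ccc3oc(-c4ccccc4)nc3c2)c1` is the next variation on this core. Its difference from compound 3 is 3-methylphenyl in place of 4-methoxyphenyl on a sulfonyl sulfur. The three measured steps all bear on it, since each swaps one such aromatic group for another, yet none gave a readable size, so no direction can be drawn from them. Among the measured compounds shown here, the expected step that the limit leaves unreadable from compound 3 to compound 4 is therefore no step that can be seen beyond the limit. Compound 4 is expected to give about 150000 nM in this assay, in a range from 40000 nM to 500000 nM, most likely reported again only as a limit.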

Compound 4, half-maximal inhibitory concentration: > 100000 nM
Compound 4: only a limit was reported (the forecaster's own chance of this, stated with the estimate: 85%); the middle value lies beyond the limit too.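

Compound 4 also gives only a limit, so the steps to it from compound 1, compound 2 and compound 3 cannot be read: the limit of > 100000 nM in this assay, at which 4 of the 4 values shown sit.

The compounds shown leave open whether any aromatic group on the sulfonyl sulfur of the shared core gives a readable value in this assay and how such groups would rank.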